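Methyl for Hydrogen on the Fused Ring of Compound 3

The source may report more compounds than this note shows. Statements on the series, on what has been measured and on what is new or still open speak of the compounds shown alone.

Working notes on the series. Compound 3 `CC#C[C@@H](CC(=O)O)c1ccc(OC[C@H]2COc3ccccc3O2)cc1` carries the fused ring without substituent; in a functional assay on HEK293 cells for agonist activity at Free fatty acid receptor 1 (Homo sapiens), read by fluorescence and calcium flux, with a stated time of 10 min (on this read-out higher numbers stand for larger maximal responses and lower numbers for smaller maximal responses), compound 3 gives 70%, the lowest of the three measured numbers. Compound 1 `CC#C[C@@H](CC(=O)O)c1ccc(OC[C@H]2COc3c(Cl)cccc3O2)cc1` gives 81% and compound 2 `CC#C[C@@H](CC(=O)O)c1ccc(OC[C@H]2COc3cccc(Cl)c3O2)cc1` gives 95%. Taking the chloro away produced a number 11 percentage points lower from compound 1 to compound 3 (beyond the scatter) and a number 25 percentage points lower from compound 2 to compound 3 (beyond the scatter), both beyond the scatter, so a chloro on this ring has twice gone with a larger maximal response than hydrogen.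

Compound 4 `CC#C[C@@H](CC(=O)O)c1ccc(OC[C@H]2COc3ccc(C)cc3O2)cc1` is the next step from compound 3: methyl in place of hydrogen on an aromatic carbon. The two chloro steps bear on this only loosely, since the entering group is methyl and not chloro, and the numbers do not show how a methyl behaves. Both known steps point upward from compound 3, so a small rise is expected in this assay, a number 10 percentage points higher from compound 3 to compound 4 (within the scatter), which may not exceed the scatter. Compound 4 is estimated at 80%, with a range from 65% to 95%.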

Compound 4, largest response reached (Emax), in percent of the reference or control that the assay uses: 78%
Compound 4: the middle estimate sits 2 percentage points above what was measured, and the stated range covers the measured number.
By their numbers in this assay, from the lowest: compounds 3, 4 and 1 (each within the scatter of the next, the first and the last beyond it); then compound 2.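

In this assay, methyl on this aromatic carbon, meta to a fused ring and para to a fused ring, gives a number 8 percentage points higher from compound 3 to compound 4 (within the scatter) and so cannot be told apart from hydrogen at this position. The earlier steps shown here on this ring were both chloro steps and lay beyond the scatter, whereas this first methyl step does not, so a substituent on the ring does not always separate from hydrogen on this read-out. No measurement bears on the reason for this result.

The compounds shown leave open how a chloro, a methoxy or an amine on this same carbon would read. They also leave open whether methyl on the other aromatic carbons of the ring would stay within the scatter of hydrogen.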